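A few compounds are considered here, and "the series" means these few. Any claim that something is new, unique, unknown or untested is made for them only; others in the source may bear on it.

Compound 1, `Cc1ccc(-c2cn(C/C=C3\OC(=O)C(OCc4ccccc4)=C3OCc3ccccc3)nn2)cc1`: in a functional assay on MCF7 cells (Homo sapiens) for antiproliferative activity, read by MTT assay, with a stated time of 72 h (a higher number here means a weaker inhibitor, a lower number a stronger inhibitor), compound 1 gives > 100000 nM, which is a limit of the assay and not a number.
Compound 2, `O=C1O/C(=C\Cn2cc(-c3ccc(Br)cc3)nn2)C(OCc2ccccc2)=C1OCc1ccccc1`: compound 2 gives > 100000 nM, again a limit.
Compound 3, `CCCCCc1ccc(-c2cn(C/C=C3\OC(=O)C(OCc4ccccc4)=C3OCc3ccccc3)nn2)cc1`: compound 3 gives > 100000 nM, again a limit.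

All three measured compounds therefore sit at the same edge of what this assay can report (the limit of > 100000 nM in this assay, at which 3 of the 3 values shown sit), and none of them shows measurable antiproliferative activity. Compound 3 stands nowhere better or worse than the others on these numbers: it sits at the limit like the rest. Every value is a limit. The three steps among the measured compounds cannot be sized: a step that the two limits leave unreadable from compound 1 to compound 2, a step that the two limits leave unreadable from compound 1 to compound 3 and a step that the two limits leave unreadable from compound 2 to compound 3 are all unreadable.

Compound 4, `COc1ccccc1-c1cn(C/C=C2\OC(=O)C(OCc3ccccc3)=C2OCc2ccccc2)nn1`, has not been measured. It differs from compound 3 in one place: 2-methoxyphenyl in place of 4-pentylphenyl on an aromatic carbon. Going by the values given here, the measured steps that bear on this change are those where the group on the same aromatic carbon of the shared core was varied, and all of them were unreadable, so they give no direction for this step. For compound 4 the expected outcome is therefore another limit in this assay, with an estimated 100000 nM and a range of 30000 nM to 300000 nM. The estimated step of a number no higher from compound 3 to compound 4 (the limit leaves the size open) is expected to be none beyond the scatter.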

Compound 4, half-maximal inhibitory concentration: > 100000 nM
Compound 4: a limit, no number; the forecaster's own chance of this, stated with the estimate: 85%; the middle value sits exactly at the limit.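

Compound 4 sits at the same limit as compound 1, compound 2 and compound 3, so none of its steps to those three can be read in this assay: the limit of > 100000 nM in this assay, at which 4 of the 4 values shown sit.

The compounds shown leave open whether any group at this place on the shared core would give a readable number, and how large the effect of swapping these groups is.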